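The source may hold more compounds than are shown below. What is called first, only, known or untested is meant among the compounds shown, and "the series" means these compounds.

Within the data shown here, in a functional assay on MCF7 cells (Homo sapiens) for cytotoxicity, read by MTT assay, with a stated time of 72 h (on this read-out lower numbers stand for stronger inhibition and higher numbers for weaker inhibition), compound 3 `O=C1c2c[n+]([O-])c3ccccc3c2C(=O)c2c1c1ccccc1n2CCN1CCCCC1` gives 620 nM, the lowest number so far. Compound 2 `CCCN1CCN(CCCCn2c3c(c4ccccc42)C(=O)c2c[n+]([O-])c4ccccc4c2C3=O)CC1` gives 1280 nM, and compound 1 `CCCCN1CCN(CCCCn2c3c(c4ccccc42)C(=O)c2c[n+]([O-])c4ccccc4c2C3=O)CC1` gives 6900 nM. Compound 4 `O=C1c2c[n+]([O-])c3ccccc3c2C(=O)c2c1c1ccccc1n2CCCN1CCC(O)CC1` has yet to be measured, and it differs from compound 3 as follows: (4-hydroxypiperidin-1-yl)methyl in place of piperidin-1-yl on a saturated chain carbon, two bonds along the chain from an aromatic nitrogen. The measured steps show that smaller side chains have gone with lower numbers: a 5.4-fold lower number from compound 1 to compound 2 (0.73 log units; beyond the scatter), a 2.1-fold lower number from compound 2 to compound 3 (0.31 log units; beyond the scatter) and an 11-fold lower number from compound 1 to compound 3 (1.05 log units; beyond the scatter). Among the measured compounds shown here, no measured compound goes against this, but none tests this exact change. The entering group is larger than piperidin-1-yl, yet smaller than the chains in compound 1 and compound 2, so a modest rise is expected in this assay, an estimated 1.5-fold higher number from compound 3 to compound 4 (0.16 log units; within the scatter). Compound 4 is estimated at 900 nM, with an expected range from 300 nM to 2700 nM.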

Compound 4, half-maximal inhibitory concentration: 190 nM
Beside the measured number, compound 4's estimate is 4.7-fold (0.68 log units) above it, outside the stated range (below it).
By their numbers in this assay, from the lowest: compound 4; then compound 3; then compound 2; then compound 1.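

In this assay, compound 4 goes against the earlier pattern of smaller side chains giving lower numbers: the larger 3-(4-hydroxypiperidin-1-yl)propyl chain gives a 3.3-fold lower number from compound 3 to compound 4 (0.51 log units; beyond the scatter). The same chain also compares well with both piperazine-bearing chains, giving a 6.7-fold lower number from compound 2 to compound 4 (0.83 log units; beyond the scatter) and a 36-fold lower number from compound 1 to compound 4 (1.56 log units; beyond the scatter). Nothing available here explains this drop.

The step from 2-(piperidin-1-yl)ethyl to 3-(4-hydroxypiperidin-1-yl)propyl changes the chain and adds the hydroxy group together, so these compounds cannot separate the two changes. Going by these compounds, whether a methoxy group or an amine in place of the hydroxy group, or a longer chain, would keep the lower number also remains open.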